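A few compounds are considered here, and "the series" means these few. Any claim that something is new, unique, unknown or untested is made for them only; others in the source may bear on it.

Working notes on the series. Compound 1 `CN(C)CCn1cnnc1-c1cc(Oc2ccc(NC(=O)N/N=C/c3ccc(F)cc3Cl)cc2F)ccn1` gives 870 nM in a functional assay on MKN-45 cells (Homo sapiens) for cytotoxicity, read by MTT assay, with a stated time of 72 h; on this read-out lower numbers stand for stronger inhibition and higher numbers for weaker inhibition. Compound 2 `CN(C)CCn1cnnc1-c1cc(Oc2ccc(NC(=O)N/N=C/c3cccc(Cl)c3Cl)cc2F)ccn1` gives 51 nM; compound 3 `CN(C)CCn1cnnc1-c1cc(Oc2ccc(NC(=O)N/N=C/c3ccc(O)c(O)c3)cc2F)ccn1` gives 3240 nM, the highest number of the three. The steps into compound 3 were a 3.7-fold higher number from compound 1 to compound 3 (0.57 log units; beyond the scatter) and a 64-fold higher number from compound 2 to compound 3 (1.80 log units; beyond the scatter), both bringing 3,4-dihydroxyphenyl in on the carbon with the double bond to nitrogen. Compound 4 `CN(C)CCn1cnnc1-c1cc(Oc2ccc(NC(=O)N/N=C/c3c(O)ccc4ccccc34)cc2F)ccn1` leaves that group again: 2-hydroxynaphthalen-1-yl in place of 3,4-dihydroxyphenyl on a carbon with a double bond to nitrogen. Within the data shown here, since both measured steps onto 3,4-dihydroxyphenyl raised the number, a step away from it toward a larger aromatic with a single hydroxyl is expected to lower it, though no measured pair shows 2-hydroxynaphthalen-1-yl itself, so the size is uncertain. Compound 4 is therefore expected at 800 nM, range 200 nM to 3500 nM, a step of a 4.1-fold lower number from compound 3 to compound 4 (0.61 log units; beyond the scatter).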

Compound 4, half-maximal inhibitory concentration: 2020 nM
Compound 4: the middle estimate sits 2.5-fold (0.40 log units) below what was measured; measured number inside the range.
By their numbers in this assay, from the lowest: compound 2; then compound 1; then compounds 4 and 3 (each within the scatter of the next).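

The second aromatic ring of 2-hydroxynaphthalen-1-yl does not separate it from 3,4-dihydroxyphenyl at the carbon with the double bond to nitrogen (a 1.6-fold lower number from compound 3 to compound 4 (0.21 log units; within the scatter)). The gap to the halogen-bearing groups remains, large against 2,3-dichlorophenyl (a 40-fold higher number from compound 2 to compound 4 (1.60 log units; beyond the scatter)) and modest against 2-chloro-4-fluorophenyl (a 2.3-fold higher number from compound 1 to compound 4 (0.37 log units; beyond the scatter)). Among these four compounds, both chlorine-bearing groups give lower numbers than both hydroxyl-bearing groups, and none goes against this.

Open, going by these compounds, is how a methoxy group or an amine in place of the hydroxyl of 2-hydroxynaphthalen-1-yl would read, and whether 2-chloronaphthalen-1-yl would fall with the chlorine-bearing groups or the hydroxyl-bearing ones. No supporting data accompany these steps.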